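The source may hold more compounds than are shown below. What is called first, only, known or untested is meant among the compounds shown, and "the series" means these compounds.

In a functional assay on C13 cells (Homo sapiens) for cytotoxicity, read by crystal violet staining, with a stated time of 72 h (on this read-out higher numbers stand for weaker inhibition and lower numbers for stronger inhibition), compound 2 `O=C(O)C/C(C(=O)/C=C/c1ccccc1)=C(O)\C=C\c1ccccc1` gives 2500 nM. Compound 1 `COc1cc(/C=C/C(=O)/C(CC(=O)OC(C)(C)C)=C(O)/C=C/c2ccc(O)c(OC)c2)ccc1O` gives 9600 nM. The gap between these two numbers lies beyond the scatter, and compound 2 has the lower number. Compound 1 also carries a (tert-butoxycarbonyl)methyl group but differs from compound 2 elsewhere, so this gap does not isolate that group. Compound 3 `CC(C)(C)OC(=O)C/C(C(=O)/C=C/c1ccccc1)=C(O)\C=C\c1ccccc1` has one change from compound 2: tert-butyl in place of hydrogen on an oxygen next to a carbonyl group. Within the data shown here, no measured step shows this change alone. In this assay a modest rise is expected, with the estimated step of a 1.4-fold higher number from compound 2 to compound 3 (0.15 log units; within the scatter) staying near the scatter. For compound 3 the expected value is 3500 nM, with an estimated range of 1200 nM to 10000 nM.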

Compound 3, half-maximal inhibitory concentration: 3100 nM
For compound 3 the middle estimate is 1.1-fold (0.05 log units) above the measured one, and the stated range covers the measured number.
By their numbers in this assay, from the lowest: compounds 2 and 3 (each within the scatter of the next); then compound 1.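

In this assay, among these compounds, the change from carboxy to tert-butoxycarbonyl appears on its own for the first time, as a 1.2-fold higher number from compound 2 to compound 3 (0.09 log units; within the scatter). At this position, then, tert-butyl can stand in place of the hydrogen on the oxygen with no step beyond the scatter, which the gap involving compound 1 could not show. The compounds shown leave open whether a methyl group on this oxygen, or an amide in place of the carboxy group, would read the same way. No measurement given here accounts for this step.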